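The source may report more compounds than this note shows. Statements on the series, on what has been measured and on what is new or still open speak of the compounds shown alone.

Compound 2, `Cc1ccc(C2=NN(c3nc(-c4ccc(F)cc4)cs3)C(c3ccc(F)cc3)C2)s1`, was tested in a functional assay on A549 cells (Homo sapiens) for antiproliferative activity, read by XTT assay, with a stated time of 24 h (a lower number here means a stronger inhibitor, a higher number a weaker inhibitor), where compound 2 gives 125 ug/mL. Its nearest neighbour among the measured compounds is compound 1, `Fc1ccc(C2CC(c3ccc(Cl)s3)=NN2c2nc(-c3ccc(Cl)cc3)cs2)cc1`, which in this assay gives 125 ug/mL, the same figure at the digits shown and within the usual scatter of the measurement. Compound 3, `N#Cc1ccc(-c2csc(N3N=C(c4ccc(Cl)s4)CC3c3ccc(F)cc3)n2)cc1`, reaches only a limit of the assay: in this assay compound 3 gives > 500 ug/mL, a limit rather than a number. Within the data shown here, the single step measured within this set, an at least 4.0-fold higher number from compound 1 to compound 3 (0.60 log units; beyond the scatter), ends at the limit of > 500 ug/mL in this assay, at which 1 of the 3 values shown sits.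

Compound 4, `Cc1ccc(C2=NN(c3nc(-c4ccc(C(F)(F)F)cc4)cs3)C(c3ccc(F)cc3)C2)s1`, differs from compound 2 in one place: trifluoromethyl in place of fluoro on an aromatic carbon. The change sits on an aromatic carbon of a six-membered aromatic ring of carbon only, para to a large group. Among the measured compounds shown here, no measured step swaps fluoro for trifluoromethyl; the one step that exists concerns cyano in place of chloro on an aromatic carbon, so it does not bear directly on this change, and no step beyond the scatter is expected. Compound 4 is therefore expected to give roughly 150 ug/mL in this assay, between 60 ug/mL and 500 ug/mL, which amounts to an expected step of a 1.2-fold higher number from compound 2 to compound 4 (0.08 log units; within the scatter).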

Compound 4, half-maximal inhibitory concentration: > 500 ug/mL
Compound 4: a limit, no number; the forecaster's own chance of this, stated with the estimate: 25%; at least 3.3-fold (0.52 log units) between middle value and limit.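

Among these compounds, the replacement of fluoro by trifluoromethyl on an aromatic carbon of a six-membered aromatic ring of carbon only, para to a large group, brings an at least 4.0-fold higher number from compound 2 to compound 4 (0.60 log units; beyond the scatter) in this assay, so this position proves sensitive to a change that the earlier compounds did not cover. Compound 4 gives > 500 ug/mL, which is a limit and not a number, so the step fixes only a lower bound on its size. Alongside an at least 4.0-fold higher number from compound 1 to compound 3 (0.60 log units; beyond the scatter), which involves a different pair of groups, this makes two replacements on that ring that end at the same limit, and the set now has no measured number for either of those two compounds: the limit of > 500 ug/mL in this assay, at which 2 of the 4 values shown sit.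

As far as these compounds go, how far compound 3 and compound 4 lie beyond that limit stays open, so the two steps cannot be ranked against each other. Also open, from the compounds shown here alone, is whether a methoxy group, an amine or a carboxylic acid on this aromatic carbon would give a readable number, and whether any group there would give a lower number than compound 2.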